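The source may report more compounds than this note shows. Statements on the series, on what has been measured and on what is new or still open speak of the compounds shown alone.

Measured so far in an assay on Sf21 cells for inhibition of high affinity nerve growth factor receptor (Homo sapiens), read by HTRF, with a stated time of 30 min, in the presence of a further agent that is not named here; on this read-out lower numbers stand for stronger inhibition and higher numbers for weaker inhibition:
- compound 1, `CC1(C)c2[nH]nc(NC(=O)c3ccccc3)c2CN1Cc1cccc(Cl)c1`, gives 670 nM
- compound 2, `CC1(C)c2[nH]nc(NC(=O)c3ccccc3)c2CN1Cc1cccc(F)c1F`, gives 200 nM

Compound 2 holds the lower of the two numbers in this assay; its nearest neighbour is compound 1, and the step of a 3.4-fold lower number from compound 1 to compound 2 (0.53 log units; beyond the scatter) lies beyond the scatter. Compound 3, `CC1(C)c2[nH]nc(NC(=O)c3ccccc3)c2CN1Cc1ccc(F)c(F)c1`, differs from compound 2 by 3,4-difluorophenyl in place of 2,3-difluorophenyl on a saturated chain carbon bound to an amine nitrogen in a ring. Among the measured compounds shown here, no measured step exchanges one difluorophenyl for another; the only step on record, a 3.4-fold lower number from compound 1 to compound 2 (0.53 log units; beyond the scatter), exchanges one halogenated phenyl for a different one and bears on this change only loosely. The step of a 1.3-fold higher number from compound 2 to compound 3 (0.10 log units; within the scatter) from compound 2 to compound 3 is therefore expected to stay within the scatter. Compound 3 is estimated at 250 nM in this assay, within a range of 100 nM to 700 nM.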

Compound 3, half-maximal inhibitory concentration: 680 nM
Compound 3: middle estimate off by 2.7-fold (0.43 log units), on the low side, within the range that was stated.
By their numbers in this assay, from the lowest: compound 2; then compounds 1 and 3 (each within the scatter of the next).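

With the same atoms joined differently, 3,4-difluorophenyl in place of 2,3-difluorophenyl on a saturated chain carbon bound to an amine nitrogen in a ring gives a clear change in this assay (a 3.4-fold higher number from compound 2 to compound 3 (0.53 log units; beyond the scatter)), so the placing of the two fluorines alone counts here. Exchanging 3-chlorophenyl for 3,4-difluorophenyl stays within the scatter (a 1.0-fold higher number from compound 1 to compound 3 (0.01 log units; within the scatter)), so among these compounds, two fluorines do not by themselves give the lower number of compound 2. Nothing available explains this difference. As far as these compounds go, whether 2-fluorophenyl or 2,3-dichlorophenyl would match 2,3-difluorophenyl remains open.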